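Ring hydroxy to methoxy in a bicyclic lactone pair

The source may hold more compounds than are shown below. What is called first, only, known or untested is meant among the compounds shown, and "the series" means these compounds.

In a functional assay on HeLa cells (Homo sapiens) for inhibition, read by MTT assay, with a stated time of 72 h (on this read-out lower numbers stand for stronger inhibition and higher numbers for weaker inhibition), compound 1 `CO[C@@H]1[C@H]2OC(=O)C[C@H]2O[C@@H]1[C@@H](O)c1ccccc1` gives 11000 nM. Compound 2 `O=C1C[C@H]2O[C@H]([C@H](O)c3ccccc3)[C@H](O)[C@H]2O1` gives 8320 nM in this assay. Compound 2 stands within the scatter of compound 1; the gap between the two numbers does not separate them, so neither compound can be called the more active of the two on what is shown. Compound 3 `CO[C@@H]1[C@H]2OC(=O)C[C@H]2O[C@@H]1[C@H](O)c1ccccc1` is not yet measured. It differs from compound 2 by methyl in place of hydrogen on an oxygen on a saturated carbon. Among the measured compounds shown here, no step between measured compounds is on hand. For the measured compounds named here, the only guide is that compound 1, which carries the methoxy, gives 11000 nM and compound 2, which carries the hydroxy, gives 8320 nM, two numbers within the scatter of each other. The step expected in this assay is a 1.2-fold higher number from compound 2 to compound 3 (0.08 log units; within the scatter), none beyond the scatter. Compound 3 is estimated at 10000 nM, with a range from 4000 nM to 25000 nM.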

Compound 3, half-maximal inhibitory concentration: 8630 nM
The estimate for compound 3 lay 1.2-fold (0.06 log units) above the measured number, and the stated range covers the measured number.
By their numbers in this assay, from the lowest: compounds 2, 3 and 1 (each within the scatter of the next).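

Methyl in place of hydrogen on an oxygen on a saturated carbon can now be read as a single change: in this assay the result is a 1.0-fold higher number from compound 2 to compound 3 (0.02 log units; within the scatter), so hydroxy to methoxy at this position does not separate the pair. The configuration at the saturated chain carbon, drawn S in compound 1 and R in compound 3, can also be read alone, and a 1.3-fold lower number from compound 1 to compound 3 (0.11 log units; within the scatter) leaves these two drawn forms unseparated as well. This second comparison rests on one difference only: the fact that compounds 1 and 3 differ only in the configuration as drawn

Only hydrogen and methyl on this oxygen are shown, so it remains open whether a longer chain or an amine-bearing chain there would give a step beyond the scatter. As far as these compounds go, it also remains open whether the chain-carbon configuration would matter with the hydroxy in place of the methoxy.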